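The source may report more compounds than this note shows. Statements on the series, on what has been measured and on what is new or still open speak of the compounds shown alone.

Compound 1 `O=C(COCCOc1no[n+]([O-])c1S(=O)(=O)c1ccccc1)NO`: 6690 nM
Compound 2 `O=C(NO)c1ccc(Oc2no[n+]([O-])c2S(=O)(=O)c2ccccc2)cc1`: 1730 nM
Compound 3 `O=C(NO)c1cccc(Oc2no[n+]([O-])c2S(=O)(=O)c2ccccc2)c1`: 4670 nM

These three compounds were tested in a functional assay on HeLa cells (Homo sapiens) for inhibition, read by MTT assay, with a stated time of 48 h; a higher number here means a weaker inhibitor, a lower number a stronger inhibitor. They share one core and a hydroxycarbamoyl group, and they differ in what joins the two. Compound 2 has the lowest number of the set, which makes it the strongest inhibitor so far, and its gap to each of the other two lies beyond the usual scatter of repeated measurements. Compound 1 and compound 3 lie within that scatter of each other.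

The next compound to be measured is compound 4 `COc1cc(C(=O)NO)ccc1Oc1no[n+]([O-])c1S(=O)(=O)c1ccccc1`, which is built from compound 2 by a single change: methoxy in place of hydrogen on an aromatic carbon. The core and the hydroxycarbamoyl group both stay. Among the compounds with values here, none of the measured compounds carries a methoxy, so the data offer no direct guide to what this change will do. The only firm starting point is compound 2 at 1730 nM. The expected 1.3-fold higher number from compound 2 to compound 4 (0.10 log units; within the scatter) is estimated to stay within the scatter, with no firm direction. For compound 4 the estimate in this assay is 2200 nM, with an expected range from 800 nM to 6000 nM.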

Compound 4, half-maximal inhibitory concentration: 2260 nM
Compound 4: middle estimate off by 1.0-fold (0.01 log units), on the low side; the measured number falls inside the stated range.
By their numbers in this assay, from the lowest: compounds 2 and 4 (each within the scatter of the next); then compounds 3 and 1 (each within the scatter of the next).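

In this assay the change gives a 1.3-fold higher number from compound 2 to compound 4 (0.12 log units; within the scatter) and that step lies within the usual scatter of repeated measurements, so compound 2 and compound 4 cannot be told apart here. The earlier compounds shown here differed only in what joins the shared core to the hydroxycarbamoyl group, so they said nothing about adding a group to the aromatic ring of compound 2; this pair shows that a methoxy on an aromatic carbon, ortho to a large group and meta to the hydroxycarbamoyl group, leaves the reading without any change that can be distinguished from scatter. Nothing available explains why the number holds, so the result stands as an observation only.

From the compounds shown here alone, whether another group at this same carbon, such as an ethoxy group, a hydroxyl, an amine or a fluorine atom, would shift the number beyond the scatter remains open. Also open, going by these compounds, is whether a methoxy on a different carbon of the same ring would leave the reading just as undisturbed.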